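Formyl series: bromo in place of nitro on the phenyl

The compounds below may be only part of what the source reports. "The series", "measured", "known", "first", "only" and "open" are said of these compounds alone.

Measured so far:
compound 1, `O=Cc1c(-c2ccc([N+](=O)[O-])cc2)nc2sc(Cc3ccccc3)nn12` — 2900 nM
compound 2, `O=[N+]([O-])c1ccc(-c2nc3sc(Cc4ccccc4)nn3c2Br)cc1` — 12600 nM

Both numbers come from a functional assay on NSCLC cells (Homo sapiens) for inhibition; on this read-out higher numbers stand for weaker inhibition of growth and lower numbers for stronger inhibition of growth. Going by the values given here, compound 1 holds the lower of the two; the only step recorded is a 4.3-fold higher number from compound 1 to compound 2 (0.64 log units; beyond the scatter), bromo in place of formyl on an aromatic carbon of the shared core. Compound 3, `O=Cc1c(-c2ccc(Br)cc2)nc2sc(Cc3ccccc3)nn12`, keeps the formyl and changes the pendant ring instead: bromo in place of nitro on an aromatic carbon. Among the compounds with values here, no measured pair shows this exchange, and the one known step concerns a different group at a different place, so it offers no direct guide in this assay. With nothing to anchor a shift, compound 3 is expected to sit near compound 1, the step of a 1.4-fold higher number from compound 1 to compound 3 (0.14 log units; within the scatter) being expected to stay within the scatter or only a little beyond it. Compound 3 is therefore estimated at 4000 nM, with a range from 1500 nM to 12000 nM.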

Compound 3, concentration for 50% growth inhibition: 4200 nM
Beside the measured number, compound 3's estimate is 1.1-fold (0.02 log units) below it, and the stated range covers the measured number.
By their numbers in this assay, from the lowest: compounds 1 and 3 (each within the scatter of the next); then compound 2.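

In this assay, going by these compounds alone, the pendant ring is read for the first time: the exchange gives a 1.4-fold higher number from compound 1 to compound 3 (0.16 log units; within the scatter) for bromo in place of nitro on an aromatic carbon, para to a large group. With the formyl kept, this position therefore tolerates the loss of the nitro group and its hydrogen-bond acceptors without a change beyond the scatter, whereas the earlier exchange at the formyl carbon gave a 4.3-fold higher number from compound 1 to compound 2 (0.64 log units; beyond the scatter) and did go beyond it. Nothing available explains either result.

From the compounds shown here alone, two compounds at this position say little about its range, so it remains open whether an amine or a carboxylic acid here would also stay within the scatter of compound 1. Going by these compounds, it is also open whether the same exchange on the phenyl would read alike with bromo in place of the formyl.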